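The compounds below may be only part of what the source reports. "The series", "measured", "known", "first", "only" and "open" are said of these compounds alone.

Three compounds share one core and differ in the group attached to the amide-type nitrogen. Compound 1 `CC(C)n1ncc2c(C(=O)Nc3cccnc3)cccc21` carries a pyridin-3-yl there. In a functional assay on MGC-803 cells (Homo sapiens) for inhibition, read by MTT assay, with a stated time of 72 h (a higher number here means a weaker inhibitor, a lower number a stronger inhibitor), compound 1 gives only the limit of the assay, > 40000 nM. Compound 2 `CC(C)n1ncc2c(C(=O)NCc3ccccc3)cccc21` carries a benzyl in place of the pyridin-3-yl. In this assay compound 2 likewise reaches only the limit, > 40000 nM. The step that the two limits leave unreadable from compound 1 to compound 2 therefore cannot be read. Compound 3 `CC(C)n1ncc2c(C(=O)NCc3cn(-c4cccc(F)c4)nn3)cccc21` carries on the amide-type nitrogen a larger group that includes a five-membered aromatic ring with 3 nitrogen, bearing a 3-fluorophenyl on an aromatic nitrogen. In this assay compound 3 also stands only at the limit, > 40000 nM. Compound 3 thus sits exactly where every measured value sits, because of the limit of > 40000 nM in this assay, at which 3 of the 3 values shown sit.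

Compound 4 `CC(C)n1ncc2c(C(=O)NCc3cn(Cc4ccc(C#N)cc4)nn3)cccc21` differs from compound 3 in one place: 4-cyanobenzyl in place of 3-fluorophenyl on an aromatic nitrogen. Among the measured compounds shown here, no measured step touches this aromatic nitrogen, and the one recorded step, from compound 1 to compound 2, is itself unreadable, so nothing shows that a change in this part of the molecule moves the number beyond the scatter. The step expected from the estimate, a step that the limit leaves unreadable from compound 3 to compound 4, is therefore taken as essentially none. The estimate for compound 4 in this assay is 50000 nM, with an expected range from 15000 nM to 200000 nM, and most likely the assay will again report only a limit.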

Compound 4, half-maximal inhibitory concentration: 39600 nM
The estimate for compound 4 lay 1.3-fold (0.10 log units) above the measured number; measured number inside the range.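

In this assay compound 4 is the first of the compounds shown to give a number rather than a limit, 39600 nM. Among the compounds shown here, on this aromatic nitrogen, 4-cyanobenzyl in place of 3-fluorophenyl gives a number no higher from compound 3 to compound 4 (the limit leaves the size open), so this position yields the first step with a readable direction, although whether that step exceeds the usual scatter cannot be told. The other three compounds offer no number to set beside that of compound 4: the limit of > 40000 nM in this assay, at which 3 of the 4 values shown sit.

The change replaces a ring bound directly to the aromatic nitrogen with a benzyl group and also exchanges the fluorine for a nitrile, and the compounds shown do not separate these two differences. Going by these compounds, it also remains open how an unsubstituted benzyl, a 4-aminobenzyl or a 4-carboxybenzyl on this aromatic nitrogen would read in this assay, and whether any such group would move the number clearly away from the limit.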